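Furan for thiophene on a pyridine core: a second look

The source may hold more compounds than are shown below. What is called first, only, known or untested is meant among the compounds shown, and "the series" means these compounds.

Compound 1 `Oc1cccc(-c2cc(-c3ccccc3)cc(-c3ccsc3)n2)c1`: 7660 nM
Compound 2 `Oc1cccc(-c2cc(-c3ccccc3)cc(-c3ccco3)n2)c1`: 13500 nM
Compound 3 `Oc1cccc(-c2cc(-c3ccccc3)nc(-c3ccsc3)c2)c1`: 24600 nM

All three were tested in a functional assay on HCT-15 cells (Homo sapiens) for cytotoxicity, read by ELISA, with a stated time of 2 days; a lower number here means a stronger inhibitor, a higher number a weaker inhibitor. Compound 1 and compound 2 differ by furan-2-yl in place of thiophen-3-yl on an aromatic carbon; this step gave a 1.8-fold higher number from compound 1 to compound 2 (0.25 log units; within the scatter). Compound 3 shares its atoms with compound 1 but joins them differently; the difference between the two cores is not broken down here. In this assay compound 3 gives 24600 nM.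

Compound 4 `Oc1cccc(-c2cc(-c3ccccc3)nc(-c3ccco3)c2)c1` is not yet measured. It differs from compound 3 by furan-2-yl in place of thiophen-3-yl on an aromatic carbon, the same change as from compound 1 to compound 2. Because a 1.8-fold higher number from compound 1 to compound 2 (0.25 log units; within the scatter) stayed within the scatter, the step for compound 4 is expected to be about a 1.4-fold higher number from compound 3 to compound 4 (0.15 log units; within the scatter). Compound 4 is therefore estimated at 35000 nM, between 15000 nM and 80000 nM.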

Compound 4, half-maximal inhibitory concentration: 13900 nM
For compound 4 the middle estimate is 2.5-fold (0.40 log units) above the measured one; the whole stated range lies above it.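

Placing furan-2-yl in place of thiophen-3-yl on the core of compound 3 gave a 1.8-fold lower number from compound 3 to compound 4 (0.25 log units; within the scatter) in this assay. Set beside the earlier step, the same change did not carry over in the same way from one core to the other: the same change on two cores in this assay, a 1.8-fold higher number (0.25 log units; within the scatter) from compound 1 to compound 2 and a 1.8-fold lower number (0.25 log units; within the scatter) from compound 3 to compound 4, 3.1-fold (0.49 log units) apart, beyond the scatter of two such steps. For the compounds shown here, each step alone stays within the scatter, so the result shows only that the two steps differ; with one pair on each core, it does not show how the core alters the change or whether the difference extends to other groups.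

The compounds shown leave open how each core would respond to an amine or a carboxylic acid on that aromatic carbon. Also open, from the compounds shown here alone, is whether a methoxy group in place of the hydroxyl of the 3-hydroxyphenyl group would change the picture.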